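Amine substituent variation on the shared core

The source may hold more compounds than are shown below. What is called first, only, known or untested is meant among the compounds shown, and "the series" means these compounds.

Measured in an assay on CHO cells for displacement of a labelled ligand from 5-hydroxytryptamine receptor 1D (Homo sapiens); on this read-out higher numbers stand for weaker inhibition and lower numbers for stronger inhibition:
compound 1 `O=S(=O)(NCC1CCN(CCCc2c[nH]c3ccc(-n4cnnc4)cc23)CC1)c1ccccc1` gives 6.2 nM
compound 2 `O[C@@H]1Cc2ccccc2[C@H]1NC1CCN(CCCc2c[nH]c3ccc(-n4cnnc4)cc23)CC1` gives 6.6 nM
compound 3 `c1cc(CNC2CCN(CCCc3c[nH]c4ccc(-n5cnnc5)cc34)CC2)co1` gives 4.5 nM

Compound 3 gives the lowest of the three numbers, yet a 1.4-fold lower number from compound 1 to compound 3 (0.14 log units; within the scatter) and a 1.5-fold lower number from compound 2 to compound 3 (0.17 log units; within the scatter) both stay within the scatter, so no order among the three is supported.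

Compound 4 `CC(C)=CCN(C)C1CCN(CCCc2c[nH]c3ccc(-n4cnnc4)cc23)CC1` differs from compound 3 by methyl(3-methylbut-2-en-1-yl)amino in place of ((furan-3-yl)methyl)amino on a saturated ring carbon. Among the compounds with values here, the steps that bear on this position, a 1.1-fold higher number from compound 1 to compound 2 (0.03 log units; within the scatter), a 1.4-fold lower number from compound 1 to compound 3 (0.14 log units; within the scatter) and a 1.5-fold lower number from compound 2 to compound 3 (0.17 log units; within the scatter), all lie within the scatter across three different groups on the same saturated ring carbon. Within the data shown here, no measured step covers a group with no ring and 0 hydrogen-bond donors, so that part of the change is untested. The expectation is therefore a step of no more than the scatter, a 1.8-fold higher number from compound 3 to compound 4 (0.25 log units; within the scatter), with a widened range. Compound 4 is estimated at 8 nM in this assay, between 3 nM and 25 nM.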

Compound 4, half-maximal inhibitory concentration: 0.5 nM
The estimate for compound 4 lay 16-fold (1.20 log units) above the measured number; the measured number lies below the stated range.
By their numbers in this assay, from the lowest: compound 4; then compounds 3, 1 and 2 (each within the scatter of the next).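

The saturated ring carbon does respond to its substituent: methyl(3-methylbut-2-en-1-yl)amino gives a 9.0-fold lower number from compound 3 to compound 4 (0.95 log units; beyond the scatter) and a 13-fold lower number from compound 2 to compound 4 (1.12 log units; beyond the scatter) and a 12-fold lower number from compound 1 to compound 4 (1.09 log units; beyond the scatter) while the three earlier groups stay within the scatter of one another. Compound 4 alone carries a group with no ring and 0 hydrogen-bond donors, so these two features change together here. Nothing available explains this step.

Going by these compounds, whether the methyl on the amine or the 3-methylbut-2-en-1-yl chain carries the step remains open. Dimethylamino or a saturated 3-methylbutyl(methyl)amino group on the same carbon would separate the two.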